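A few compounds are considered here, and "the series" means these few. Any claim that something is new, unique, unknown or untested is made for them only; others in the source may bear on it.

Compound 1 `CCN1C/C(=C\c2ccc(OC)c(OC)c2)C(=O)/C(=C/c2ccc(OC)c(OC)c2)C1` carries an ethyl group on the amine nitrogen in the ring. In an ADME assay on L02 cells (Homo sapiens) for cytotoxicity, read by MTT assay, with a stated time of 72 h (on this read-out higher numbers stand for weaker inhibition and lower numbers for stronger inhibition), compound 1 gives 9800 nM, the lowest of the three numbers measured. Compound 2 `COc1cc(/C=C2\CN(C)C/C(=C\c3cc(OC)c(OC)c(OC)c3)C2=O)cc(OC)c1OC` gives 26400 nM, and compound 3 `COc1cc(/C=C2\CN(C(=O)C(C)C)C/C(=C\c3cc(OC)c(OC)c(OC)c3)C2=O)cc(OC)c1OC` gives 12200 nM, so compound 1 and compound 3 lie within the scatter of each other, while compound 2 sits beyond it. Going by the values given here, the one step measured at this nitrogen is a 2.2-fold lower number from compound 2 to compound 3 (0.34 log units; beyond the scatter). Compound 4 `COc1ccc(/C=C2\CNC/C(=C\c3ccc(OC)c(OC)c3)C2=O)cc1OC` differs from compound 1 by hydrogen in place of ethyl on an amine nitrogen in a ring. Among the compounds with values here, no measured step removes the substituent altogether, so the data give no firm direction. The expected step is a 1.2-fold higher number from compound 1 to compound 4 (0.09 log units; within the scatter), nothing beyond the scatter. Compound 4 is estimated at 12000 nM, with a range from 4500 nM to 32000 nM.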

Compound 4, half-maximal inhibitory concentration: 15100 nM
For compound 4 the middle estimate is 1.3-fold (0.10 log units) below the measured one, within the range that was stated.
By their numbers in this assay, from the lowest: compounds 1, 3, 4 and 2 (each within the scatter of the next, the first and the last beyond it).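

Going from ethyl to hydrogen on the amine nitrogen in the ring, the compounds show for the first time what happens when this substituent is removed altogether: in this assay the change gives a 1.5-fold higher number from compound 1 to compound 4 (0.19 log units; within the scatter), so the number does not depend on the ethyl group in the core of compound 1. Nothing measured here gives a reason for this result.

The compounds shown leave open whether a longer chain, such as butyl, or a chain ending in a carboxylic acid would shift the number at this nitrogen. They also leave open how hydrogen would compare with methyl on the core of compound 2.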